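Swapping a Triazole Tail for a Hydroxyethyl Amide

The source may hold more compounds than are shown below. What is called first, only, known or untested is meant among the compounds shown, and "the series" means these compounds.

Measured so far:
Compound 1 `Cn1ncc(Cl)c1-c1cc(C(=O)N[C@@H]2CN[C@H](CCn3cncn3)C[C@H]2c2ccc(Cl)c(Cl)c2)oc1Cl`: 1560 nM
Compound 2 `O=C(N[C@@H]1CNCC[C@H]1c1ccc(Cl)cc1)c1ccc(-c2ncnc3c2CCC3O)s1`: 24100 nM
Compound 3 `CC(=O)OCC[C@@H]1C[C@@H](c2ccc(F)c(F)c2)[C@H](NC(=O)c2cc(-c3c(Cl)cnn3C)c(Cl)o2)CN1`: 4960 nM

All three were tested in a functional assay on OVCAR-8 cells (Homo sapiens) for antiproliferative activity; a lower number here means a stronger inhibitor, a higher number a weaker inhibitor. Compound 1 gives the lowest number of the three; compound 3 comes nearest, yet its gap from compound 1 is beyond the usual scatter, and compound 2 sits furthest away, also well beyond it.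

Compound 4 `Cn1ncc(Cl)c1-c1cc(C(=O)N[C@@H]2CN[C@H](CC(=O)NCCO)C[C@H]2c2ccc(Cl)c(Cl)c2)oc1Cl` has not been measured yet. It differs from compound 1 in one place: (2-hydroxyethyl)carbamoyl in place of (1H-1,2,4-triazol-1-yl)methyl on a saturated chain carbon bound to a saturated ring carbon. Among the measured compounds shown here, no measured pair here shows what such a swap does, so the direction rests on judgement alone. A modest weakening is expected in this assay, a 1.7-fold higher number from compound 1 to compound 4 (0.22 log units; within the scatter), though a result inside the scatter would not be surprising. Compound 4 is therefore estimated at 2600 nM, with a likely range from 800 nM to 8500 nM.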

Compound 4, half-maximal inhibitory concentration: 1450 nM
Compound 4: the middle estimate sits 1.8-fold (0.25 log units) above what was measured, within the range that was stated.
By their numbers in this assay, from the lowest: compounds 4 and 1 (each within the scatter of the next); then compound 3; then compound 2.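

In this assay, putting (2-hydroxyethyl)carbamoyl in place of (1H-1,2,4-triazol-1-yl)methyl gives a 1.1-fold lower number from compound 1 to compound 4 (0.03 log units; within the scatter). At this saturated chain carbon, then, an open chain with a carbonyl and hydrogen-bond donors can stand in for a five-membered aromatic ring with no difference that can be told from scatter. Nothing available explains why the two groups read alike.

The compounds shown leave open whether a carboxylic acid or an amine at this position would also read alike. They also leave open whether a longer chain ending in hydroxyl would do the same.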